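The compounds below may be only part of what the source reports. "The series", "measured", "known", "first", "only" and "open" are said of these compounds alone.

Measured in an ADME assay on HEK-293T cells (Homo sapiens) for inhibition, read by CCK-8 assay, with a stated time of 48 h, tested at 20 uM; on this read-out lower numbers stand for less inhibition of growth and higher numbers for more inhibition of growth at the one concentration tested:
Compound 1 `N#C/C(=C\c1ccccc1OS(=O)(=O)c1ccc([N+](=O)[O-])cc1)C(=O)Nc1nnc(-c2cccs2)s1`: 33%
Compound 2 `N#C/C(=C\c1ccccc1OS(=O)(=O)c1ccc([N+](=O)[O-])cc1)C(=O)Nc1nnc(Cc2ccccc2)s1`: "not toxic" (no number reported)
Compound 3 `N#C/C(=C\c1ccccc1OS(=O)(=O)c1ccc(F)cc1)C(=O)Nc1nnc(Cc2ccccc2)s1`: 6%

The entry for compound 2 reads "not toxic" (no number reported), a verdict in words, so compound 2 cannot be placed on the numerical scale beside the other two. The next structure is compound 4 `N#C/C(=C\c1ccccc1OS(=O)(=O)c1ccc([N+](=O)[O-])cc1)C(=O)Nc1nnc(Cc2ccc(F)cc2)s1`. Going by the values given here, its single change is fluoro in place of hydrogen on an aromatic carbon, benzyl to 4-fluorobenzyl (fluoro in place of hydrogen on an aromatic carbon). Among the compounds with values here, no measured pair shows what this change does in this assay, so no step beyond the scatter is expected, in either direction. The closest numerical guide is compound 3, which also carries a benzyl group and gives 6%. For compound 4 the expected value is 8%, with an estimated range of 0% to 25%.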

Compound 4, percent growth inhibition at one concentration: 8%
Compound 4: middle estimate and measured number agree at the digits printed; the range from low to high includes it.
By their numbers in this assay, from the lowest: compounds 3 and 4 (each within the scatter of the next); then compound 1.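

In this assay, putting 4-fluorobenzyl in place of thiophen-2-yl gives a number 25 percentage points lower from compound 1 to compound 4 (beyond the scatter), the first readable sign that the group at this position of the shared core can shift growth inhibition. The change from hydrogen to fluoro itself cannot be read, as compound 2 has a verdict in words and no number. Nothing available explains the step from thiophen-2-yl to 4-fluorobenzyl. Still open, going by these compounds, is what fluoro alone does on the benzyl group. Also open, on these data alone, is how an amine in place of fluoro, or a longer chain in place of 4-fluorobenzyl, would read here.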